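Isopentyloxy in place of methoxy: outlook for compound 3

The source may report more compounds than this note shows. Statements on the series, on what has been measured and on what is new or still open speak of the compounds shown alone.

Measured so far:
compound 1 `CCCC1=C(OC)C(CCC)(CCC)C(=O)/C(=C(O)\C=C\c2ccccc2)C1=O` 8.2 uM
compound 2 `CCCC1=C(OC)C(CCC)(CCC)C(=O)/C(=C(O)\C=C\c2ccc(I)cc2)C1=O` 2.8 uM

In a functional assay on PC-3 cells (Homo sapiens) for antiproliferative activity, read by sulforhodamine B assay, with a stated time of 3 days (on this read-out higher numbers stand for an effect only at larger amounts of compound and lower numbers for an effect already at smaller amounts), compound 1 holds the highest of the two numbers; the nearest is compound 2, reached by a 2.9-fold lower number from compound 1 to compound 2 (0.47 log units; beyond the scatter). Compound 3 `CCCC1=C(OCCC(C)C)C(CCC)(CCC)C(=O)/C(=C(O)\C=C\c2ccccc2)C1=O` differs from compound 1 by isobutyl in place of hydrogen on a saturated chain carbon bound to an oxygen on an unsaturated carbon; read one bond further out, methoxy becomes isopentyloxy. Within the data shown here, the single measured step, from compound 1 to compound 2, alters the aromatic substituent and says nothing about the ether chain. Among the measured compounds shown here, no measured step bears on this change. For compound 3 the step from compound 1 is therefore expected to stay within the scatter, a 1.0-fold lower number from compound 1 to compound 3 (0.01 log units; within the scatter). Compound 3 is estimated at 8 uM, in the range 3 uM to 20 uM.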

Compound 3, concentration for half-maximal effect: 17 uM
Compound 3: middle estimate off by 2.1-fold (0.33 log units), on the low side; the range from low to high includes it.
By their numbers in this assay, from the lowest: compound 2; then compound 1; then compound 3.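

The ether position on the shared core responds to change: in this assay, methoxy to isopentyloxy gives a 2.1-fold higher number from compound 1 to compound 3 (0.32 log units; beyond the scatter), a modest step beyond the scatter. Among these compounds, compound 2 changed only the aromatic substituent, so this is the only reading on the ether chain, and it shows a higher number, not a lower one. Nothing at hand accounts for this step.

Only methoxy and isopentyloxy are shown here, so whether the number tracks chain length or branching remains open. How an ethoxy, a straight pentyloxy or an amine-bearing chain would read is also unknown.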